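Notes on a piperidine amide series with one measured value

The source may report more compounds than this note shows. Statements on the series, on what has been measured and on what is new or still open speak of the compounds shown alone.

The series shares one core, seen in compound 1 `COC(=O)c1cccc(C(=O)N2CCC(N(C3CC3)S(=O)(=O)c3cccc(C(F)(F)F)c3)CC2)c1`, compound 2 `CS(=O)(=O)c1ccc(C(=O)N2CCC(N(C3CC3)S(=O)(=O)c3cccc(C(F)(F)F)c3)CC2)cc1` and compound 3 `CS(=O)(=O)c1ccccc1C(=O)N1CCC(N(C2CC2)S(=O)(=O)c2cccc(C(F)(F)F)c2)CC1`; the three differ only in the aryl group on the carbonyl carbon. In an assay on cells for inhibition of Voltage-dependent L-type calcium channel subunit alpha-1C (Homo sapiens), read by FLIPR and calcium flux, tested at 1 uM (on this read-out higher numbers stand for a stronger effect at the one concentration tested and lower numbers for a weaker effect), compound 3 gives 19%, a weak effect at the single concentration. In this assay, among the compounds with values here, compound 1 gives "not determined" (no result reported), and compound 2 gives "not determined" (no result reported), so compound 2 stands without a number and cannot be placed against compound 3; no step between two measured compounds is available.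

Compound 4 `CN(C)c1cccc(C(=O)N2CCC(N(C3CC3)S(=O)(=O)c3cccc(C(F)(F)F)c3)CC2)c1` arises from compound 2 by the change (3-(dimethylamino)phenyl in place of 4-(methylsulfonyl)phenyl on a carbonyl carbon). Within the data shown here, with no measured pair to draw on, no direction for this step can be claimed; the only anchor is the weak inhibition of compound 3, and a step no larger than the usual scatter, in either direction, is the plain expectation.

On that basis compound 4 is estimated at 15% in this assay, within a range of 0% to 40%.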

Compound 4, a percentage reported as inhibition, at one concentration (the size of the read-out at that concentration, not a potency): 40%
The estimate for compound 4 lay 25 percentage points below the measured number; the measured number falls inside the stated range.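

In this assay the aryl group on the carbonyl carbon now shows an effect that can be read, with a number 21 percentage points higher from compound 3 to compound 4 (beyond the scatter) when 3-(dimethylamino)phenyl takes the place of 2-(methylsulfonyl)phenyl. The step from compound 2 to compound 4 cannot be read, as compound 2 has no number. Nothing at hand gives a cause for the rise on this change.

The two aryl groups differ both in the substituent and in the numbers in their names, and the compounds shown do not separate these two changes, as neither 2-(dimethylamino)phenyl nor 3-(methylsulfonyl)phenyl is among them with a value. Going by these compounds, how a carboxylic acid, a primary amine or a morpholine at this place on the carbonyl carbon would read also stays open.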